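This account rests on a few compounds, and the source may have more. Where it says the series, first, only, none or still open, it means among the compounds named here.

Series notes.

Compound 1 `Cc1ccc(-c2cc(NO)c(C(=O)Nc3ccccc3)c(=O)o2)cc1`: in an ADME assay on Huh-7 cells (Homo sapiens) for cytotoxicity, read by a luciferase reporter and WST assay, with a stated time of 3 days (on this read-out higher numbers stand for lower toxicity in this test and lower numbers for higher toxicity in this test), compound 1 gives > 20000 nM, which is a limit of the assay and not a number.
Compound 2 `Cc1ccc(NC(=O)c2c(NO)cc(-c3ccccc3)oc2=O)cc1`: in this assay compound 2 gives > 20000 nM, again a limit.
Compound 3 `Cc1ccc(NC(=O)c2c(NO)cc(-c3ccc(Cl)cc3)oc2=O)cc1`: in this assay compound 3 gives > 20000 nM, also a limit.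

Compound 3 therefore stands at the limit of this assay, and it does not stand alone there: the limit of > 20000 nM in this assay, at which 3 of the 3 values shown sit. No value in the set is a readable number, and no ranking among the three compounds can be drawn.

Compound 4 `Cc1ccc(NC(=O)c2c(NO)cc(-c3ccc(C)cc3)oc2=O)cc1` is the next member. Relative to compound 3 the change is methyl in place of chloro on an aromatic carbon.

For the measured compounds named here, the only measured step that touches the same position is a step that the two limits leave unreadable from compound 2 to compound 3, and since both of its ends are limits its size cannot be read. Nothing else in the set bears on an exchange at this position. There is thus no measured basis for expecting movement in this assay in either direction; the expectation is no step beyond the scatter, with the most likely outcome a further limit.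

The step that the limit leaves unreadable from compound 3 to compound 4 is expected to be none readable.

Compound 4 is estimated at 30000 nM in this assay, with a range from 15000 nM to 80000 nM.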

Compound 4, half-maximal cytotoxic concentration: > 20000 nM
Compound 4 was reported as a limit; the forecaster's own chance of this, stated with the estimate: 85%; the middle value is on the limit's open side.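

In this assay compound 4 gives > 20000 nM, a limit and not a number. No step from compound 1, compound 2 or compound 3 to compound 4 can be read: the limit of > 20000 nM in this assay, at which 4 of the 4 values shown sit.

The compounds shown leave open whether hydrogen, chloro and methyl differ at all in this assay, and at what concentration any of these compounds would give a readable value.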